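Removing a Methoxy Group From the Pyridine Amide

A few compounds are considered here, and "the series" means these few. Any claim that something is new, unique, unknown or untested is made for them only; others in the source may bear on it.

Compound 1 `COc1cc(N(C)CCN(C)C)c(NC(=O)c2ccncc2)cc1Nc1nccc(-c2cn(C)c3ccccc23)n1`, compound 2 `COc1cc(N(C)CCN(C)C)c(NC(=O)c2ccncc2OC)cc1Nc1nccc(-c2cn(C)c3ccccc23)n1` and compound 3 `COc1ccc(C(=O)Nc2cc(Nc3nccc(-c4cn(C)c5ccccc45)n3)c(OC)cc2N(C)C)nc1` differ in the amide part of the molecule. In a functional assay on NCI-H1975 cells (Homo sapiens) for antiproliferative activity, read by MTT assay, with a stated time of 72 h (on this read-out higher numbers stand for weaker inhibition and lower numbers for stronger inhibition), compound 2 gives 1010 nM, while compound 3 gives 2130 nM and compound 1 gives 6860 nM. The difference between the cores of compound 2 and compound 3 is not broken down here. From compound 2 to compound 1 the change is hydrogen in place of methoxy on an aromatic carbon, and it made a 6.8-fold higher number from compound 2 to compound 1 (0.83 log units; beyond the scatter). Compound 4 `COc1cc(N(C)C)c(NC(=O)c2ccccn2)cc1Nc1nccc(-c2cn(C)c3ccccc23)n1` arises from compound 3 by hydrogen in place of methoxy on an aromatic carbon. The place is not the same: ortho to a large group in the first pair, para to a large group in the second, so this is the same kind of change, not the same. Compound 4 is expected to give about 6000 nM in this assay. The expected step, a 2.8-fold higher number from compound 3 to compound 4 (0.45 log units; beyond the scatter), is set somewhat smaller than the measured step of a 6.8-fold higher number from compound 2 to compound 1 (0.83 log units; beyond the scatter), which rests on a single pair at a different place.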

Compound 4, half-maximal inhibitory concentration: 10400 nM
Beside the measured number, compound 4's estimate is 1.7-fold (0.24 log units) below it; low and high end bracket the measured number.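

In this assay, replacing the methoxy group of the 5-methoxypyridin-2-yl amide with hydrogen gave a 4.9-fold higher number from compound 3 to compound 4 (0.69 log units; beyond the scatter) and so weakened inhibition on this second core as well. The two steps agree in size: the same change on two cores in this assay, a 6.8-fold higher number (0.83 log units; beyond the scatter) from compound 2 to compound 1 and a 4.9-fold higher number (0.69 log units; beyond the scatter) from compound 3 to compound 4, 1.4-fold (0.14 log units) apart, within the scatter of two such steps. This shows that the change carried over between these two cores with a similar loss, even though the methoxy group sat at a different place in each pair, but two pairs cannot show that it would hold on other cores in the series. The compounds shown leave open whether another group at the same place, such as ethoxy, a fluorine atom or an amine, would do as well as methoxy.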